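Compound 3 and the Move to Two Methyl Groups

The source may hold more compounds than are shown below. What is called first, only, known or untested is meant among the compounds shown, and "the series" means these compounds.

Three compounds of one series share a core in which an amide is tied to a ring nitrogen that carries an aromatic group. Compound 1 `COc1ccc(N2CCN(CCNC(=O)c3cccnc3)CC2)cc1` gives 1620 nM in a functional assay for antagonist activity at Adrenergic receptor alpha-1 (Rattus norvegicus); on this read-out higher numbers stand for weaker binding and lower numbers for tighter binding. Compound 2 `Cc1ccc(N2CCN(CCNC(=O)c3cccnc3)CC2)cc1` gives 295 nM in this assay, and compound 3 `COc1ccc(N2CCN(CCNC(=O)c3ccco3)CC2)cc1` gives 14.1 nM. Compound 3 therefore holds the lowest number of the three, below compound 2 and well below compound 1, both gaps lying beyond the scatter. For the measured compounds named here, the two single-point steps so far are a 5.5-fold lower number from compound 1 to compound 2 (0.74 log units; beyond the scatter) and a 110-fold lower number from compound 1 to compound 3 (2.06 log units; beyond the scatter).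

Compound 4 `Cc1ccc(N2CCN(CCNC(=O)c3ccco3)CC2)c(C)c1` has not yet been measured in this assay. It differs from compound 3 in one place: 2,4-dimethylphenyl in place of 4-methoxyphenyl on an amine nitrogen in a ring. Going by the values given here, only one measured step bears on this change, the exchange of methoxy for methyl, which is a 5.5-fold lower number from compound 1 to compound 2 (0.74 log units; beyond the scatter), a modest move. Among the compounds with values here, the second methyl group of the 2,4-dimethylphenyl has no counterpart among the measured compounds, so its contribution is unknown. On the strength of the methyl-for-methoxy step alone, a modest drop in the number is expected, a 2.4-fold lower number from compound 3 to compound 4 (0.37 log units; beyond the scatter). Compound 4 is thus estimated at 6 nM in this assay, with a range from 1.5 nM to 25 nM.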

Compound 4, dissociation constant: 19.1 nM
For compound 4 the middle estimate is 3.2-fold (0.50 log units) below the measured one; measured number inside the range.
By their numbers in this assay, from the lowest: compounds 3 and 4 (each within the scatter of the next); then compound 2; then compound 1.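

With the furan-2-yl amide held in place, 2,4-dimethylphenyl in place of 4-methoxyphenyl on the amine nitrogen in a ring gives a 1.4-fold higher number from compound 3 to compound 4 (0.13 log units; within the scatter) in this assay, so this assay does not tell these two aromatic groups apart on this amide, and a number at this level does not depend on the methoxy oxygen. For the compounds shown here, the only earlier change at this position, on the pyridin-3-yl amide, was a 5.5-fold lower number from compound 1 to compound 2 (0.74 log units; beyond the scatter), a step beyond the scatter, although that change brought in one methyl group and the new one brings in the 2,4-dimethyl pattern, so the two steps are not the same exchange. Nothing available here gives a measured reason for this result.

The compounds shown leave open whether a 4-methylphenyl group on the furan-2-yl amide, or a 2,4-dimethylphenyl group on the pyridin-3-yl amide, would separate the part played by the second methyl group from that of the amide partner. They also leave open how groups of another kind at this position, such as 4-chlorophenyl or an unsubstituted phenyl, would read in this assay.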